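This account rests on a few compounds, and the source may have more. Where it says the series, first, only, none or still open, it means among the compounds named here.

Three compounds share one saturated core bearing a secondary amine, and each carries a different aromatic group on the saturated chain carbon bound to that amine. Compound 1 `CCc1csc(CN[C@@H]2C[C@H]3C[C@@H]([C@H]2C)C3(C)C)c1` gives in an ADME assay on MDCK cells (Canis lupus familiaris) for cytotoxicity, read by microscopy, with a stated time of 48 h (on this read-out higher numbers stand for lower toxicity in this test and lower numbers for higher toxicity in this test), a value of 25000 nM. Compound 3 `C[C@H]1[C@H](NCc2sccc2-c2ccccc2)C[C@H]2C[C@@H]1C2(C)C` gives in this assay a value of 12500 nM. Compound 2 `C[C@H]1[C@H](NCc2cncnc2)C[C@H]2C[C@@H]1C2(C)C` is different: in this assay compound 2 gives only > 100000 nM, which is a limit of the test and not a measured number. Among the measured compounds shown here, compound 2 therefore stands at the limit of > 100000 nM in this assay, at which 1 of the 3 values shown sits, and among the three results it is the one without a value of its own.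

Compound 4 `Cc1ccc(CN[C@@H]2C[C@H]3C[C@@H]([C@H]2C)C3(C)C)s1` has not yet been tested. It differs from compound 2 in a single place: 5-methylthiophen-2-yl in place of pyrimidin-5-yl on a saturated chain carbon bound to an amine nitrogen. For the measured compounds named here, no measured step between two tested compounds covers this exchange, so the expectation must lean on the other results. Compound 4 is closest in shape to compound 1, and because in this assay compound 1 gives 25000 nM, compound 4 is expected to show a measurable value, a step of an at least 3.3-fold lower number from compound 2 to compound 4 (0.52 log units; beyond the scatter) toward higher toxicity. The estimate for compound 4 in this assay is 30000 nM, expected to fall between 10000 nM and 100000 nM.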

Compound 4, minimum cytotoxic concentration: 780 nM
For compound 4 the middle estimate is 38-fold (1.59 log units) above the measured one; measured number below the stated range.
By their numbers in this assay, from the lowest: compound 4; then compounds 3 and 1 (each within the scatter of the next). At a limit, above all of these: compound 2.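

Exchanging pyrimidin-5-yl for 5-methylthiophen-2-yl on a saturated chain carbon bound to an amine nitrogen gives an at least 120-fold lower number from compound 2 to compound 4 (2.10 log units; beyond the scatter) in this assay, so a single exchange at this position can change this read-out by a large amount. As far as these compounds go, the true size of the step remains unknown because compound 2 gives only a limit: the limit of > 100000 nM in this assay, at which 1 of the 4 values shown sits. Compound 4 at 780 nM also stands well apart from compound 1 at 25000 nM and compound 3 at 12500 nM, which shows that groups other than pyrimidin-5-yl do not share one level of toxicity in this test.

The compounds shown leave open how much of the step belongs to the ring and how much to its methyl group, which an unsubstituted thiophen-2-yl or a phenyl on the same carbon could separate. They also leave open whether this exchange would have the same effect on a different core.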